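Carboxy in Place of Hydroxy: What Compound 4 May Show

The compounds below may be only part of what the source reports. "The series", "measured", "known", "first", "only" and "open" are said of these compounds alone.

Of the compounds shown here, three built on a shared core have been measured in a functional assay on A-375 cells (Homo sapiens) for antiproliferative activity, read by MTT assay, with a stated time of 24 h, tested at 0.41 ug/mL; on this read-out lower numbers stand for a weaker effect and higher numbers for a stronger effect at the one concentration tested. Compound 1 `CCc1ccc2nc(C(=O)Nc3c(F)cc(-c4cccc(F)c4)cc3F)c(C)c(O)c2c1` gives 3.56%. Compound 3 `CCc1ccc2nc(C(=O)Nc3c(F)cc(-c4cccc(F)c4)cc3F)c(C)c(C(=O)O)c2c1`, which carries carboxy in place of hydroxy on an aromatic carbon, gives 6.13%, so that the step of a number 2.6 percentage points higher from compound 1 to compound 3 (within the scatter). Compound 2 `COc1ccc2nc(C(=O)Nc3ccc(-c4ccccc4)cc3)c(C)c(O)c2c1` gives 7.62%; the difference between the core of compound 2 and the core of compound 1 is not broken down here, and the three values all lie within the scatter of one another, so no order among them can be read.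

Compound 4 `COc1ccc2nc(C(=O)Nc3ccc(-c4ccccc4)cc3)c(C)c(C(=O)O)c2c1` has not yet been measured in this assay. It differs from compound 2 by carboxy in place of hydroxy on an aromatic carbon. This is the same change that separates compound 3 from compound 1, and it sits in the same place, with the same surroundings described in the same words.

For the measured compounds named here, since the one measured example of this change, a number 2.6 percentage points higher from compound 1 to compound 3 (within the scatter), stayed within the scatter, the corresponding step of a number 1.9 percentage points higher from compound 2 to compound 4 (within the scatter) is expected to be of similar, small size. Because compound 2 gives 7.62%, compound 4 is expected to reach about 9.5% in this assay, with a plausible range from 2% to 18%. This rests on a single prior example, so the expectation is weakly founded, and the measurement will show whether the change again leaves the read-out essentially unmoved.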

Compound 4, a percentage reported as inhibition, at one concentration (the size of the read-out at that concentration, not a potency): 11.3%
For compound 4 the middle estimate is 1.8 percentage points below the measured one; the range from low to high includes it.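

In this assay, carboxy in place of hydroxy on an aromatic carbon gives, on the core of compound 2, a number 3.7 percentage points higher from compound 2 to compound 4 (within the scatter). Set beside the step on the core of compound 1, this second step agrees with the first as closely as such measurements can tell: the same change on two cores in this assay, a number 2.6 percentage points higher (within the scatter) from compound 1 to compound 3 and a number 3.7 percentage points higher (within the scatter) from compound 2 to compound 4, 1.1 percentage points apart, within the scatter of two such steps

The change thus carries from one core to the other without a step that can be told from the scatter on either, but this does not show that it truly raises the read-out on either core, and two pairs read at a single concentration say nothing about potency or about whether the two cores would still match if the effect were larger.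

The compounds shown leave open what other groups would do on that aromatic carbon, such as an amine, a methyl ester or a primary amide, for only hydroxy and carboxy appear there. Also open, as far as these compounds go, is how the same change would behave with a longer chain in place of the methyl group, or with a chlorine atom in place of the fluorine atoms on the core of compound 1.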